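Bis-azetidinyl analogue in the cyclobutyloxy series

A few compounds are considered here, and "the series" means these few. Any claim that something is new, unique, unknown or untested is made for them only; others in the source may bear on it.

Within the data shown here, the series so far holds two measured compounds that share one core and differ only in which of the two four-membered substituents sits on which carbon. Compound 1 `CCCCCCCCCCCCCCc1nc(N2CCC2)nc(OC2CCC2)c1O` carries an azetidin-1-yl and a cyclobutyloxy group; compound 2 `CCCCCCCCCCCCCCc1nc(OC2CCC2)nc(N2CCC2)c1O` carries the same two groups with their positions exchanged. In a functional assay on cells (Lymphocyte, Homo sapiens), read by a luciferase reporter and ATP content, with a stated time of 48 h, tested at 1 uM (a higher number here means a weaker effect of the compound at the concentration tested, a lower number a stronger effect), compound 1 gives 105%, and in the same assay compound 2 gives 109%. The two numbers lie within the usual scatter of one another, so compound 2 does not stand apart from compound 1 on this read-out; both sit at the level where the compound shows little effect at the concentration tested.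

Compound 3 `CCCCCCCCCCCCCCc1nc(N2CCC2)nc(N2CCC2)c1O` has not yet been measured. Relative to compound 2 the change is azetidin-1-yl in place of cyclobutyloxy on an aromatic carbon, so that both four-membered substituents are now azetidin-1-yl.

Among the measured compounds shown here, no step between measured compounds exists to guide the size of the expected change. Since compound 1 and compound 2 give values within the scatter of each other regardless of where the azetidin-1-yl sits, the expected step for compound 3 is none beyond the scatter, a number 4 percentage points lower from compound 2 to compound 3 (within the scatter). For compound 3 the estimate in this assay is 105%, with a range from 92% to 118%.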

Compound 3, a percentage reported as activity, at one concentration (the size of the read-out at that concentration, not a potency): 86%
Compound 3: middle estimate off by 19 percentage points, on the high side; the measured number lies below the stated range.
By their numbers in this assay, from the lowest: compound 3; then compounds 1 and 2 (each within the scatter of the next).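

In this assay the exchange of cyclobutyloxy for azetidin-1-yl on the aromatic carbon between two ring nitrogen atoms, para to a hydroxy group, gives a number 23 percentage points lower from compound 2 to compound 3 (beyond the scatter) and so marks a stronger effect at the concentration tested. The same exchange on the other cyclobutyloxy-bearing carbon, starting from compound 1, gives a number 19 percentage points lower from compound 1 to compound 3 (beyond the scatter) and ends at the same bis-azetidinyl compound. Swapping the two groups between their positions had left the read-out within the scatter, whereas a second azetidin-1-yl in place of cyclobutyloxy moves it beyond the scatter from either starting compound, although these steps rest on compound 3 alone. No measurement at hand accounts for this step.

From the compounds shown here alone, it remains open whether the lower number is specific to azetidin-1-yl or would also appear with another amine on these carbons, such as pyrrolidin-1-yl or dimethylamino. The read-out at one concentration also leaves open how compound 3 would behave across a range of concentrations, and whether a shorter alkyl chain on the shared core would preserve the step.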